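Swapping a methoxypyridinyl for phenyl on a shared core

This account rests on a few compounds, and the source may have more. Where it says the series, first, only, none or still open, it means among the compounds named here.

Measured compounds:
- compound 1, `CNc1nc(NCCCN(C)C)c2sc(-c3ccc(-n4cccn4)cc3)cc2n1`: 1.66 h
- compound 2, `CNc1nc(NCCCN(C)C)c2sc(-c3ccc(OC)nc3)cc2n1`: 3.02 h
- compound 3, `CNc1nc(NCCCN(C)C)c2sc(-c3cccc4cnccc34)cc2n1`: 0.422 h

Three compounds share a core and differ only in the aryl group attached to it. In an ADME assay (liver) for metabolic stability, with Liver microsome (Homo sapiens) as the target, read by LC-MS, using microsomes, tested at 1 uM (a lower number here means that the compound disappears faster, a higher number that the compound lasts longer), compound 2 gives 3.02 h, the highest of the three numbers. Compound 1 gives 1.66 h, which lies within the scatter of the value of compound 2, so no order can be read between these two. Compound 3 gives 0.422 h, and that gap to compound 2 lies beyond the scatter.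

Compound 4, `CNc1nc(NCCCN(C)C)c2sc(-c3ccccc3)cc2n1`, is not yet measured. It differs from compound 2 in one place: phenyl in place of 6-methoxypyridin-3-yl on an aromatic carbon next to the ring sulfur. For the measured compounds named here, no pair of measured compounds isolates this kind of change, so the three measured values are the only guide. Given that all three aryl variants fall in a band set by compound 2 at 3.02 h and compound 3 at 0.422 h, compound 4 is expected to land inside that band, with a step of a 2.0-fold lower number from compound 2 to compound 4 (0.30 log units; within the scatter) in this assay. Compound 4 is therefore estimated at 1.5 h, with a range from 0.6 h to 4 h.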

Compound 4, half-life: 5.75 h
For compound 4 the middle estimate is 3.8-fold (0.58 log units) below the measured one; measured number above the stated range.
By their numbers in this assay, from the lowest: compound 3; then compounds 1, 2 and 4 (each within the scatter of the next, the first and the last beyond it).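

In this assay, the exchange of 6-methoxypyridin-3-yl for phenyl on the aromatic carbon next to the ring sulfur amounts to a 1.9-fold higher number from compound 2 to compound 4 (0.28 log units; within the scatter), so these two groups cannot be told apart at this position. The unsubstituted phenyl does separate from the aryl group of compound 1: hydrogen in place of 1H-pyrazol-1-yl on an aromatic carbon gives a 3.5-fold higher number from compound 1 to compound 4 (0.54 log units; beyond the scatter), which shows that this single group on the phenyl ring matters for the half-life, though only modestly. Nothing at hand explains either step.

The compounds shown leave open whether a smaller group on the phenyl ring, such as a fluorine atom or a nitrile, would behave like 1H-pyrazol-1-yl or like hydrogen. They also leave open how a plain pyridine without the methoxy group would compare with compound 2 and compound 4.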